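The source may report more compounds than this note shows. Statements on the series, on what has been measured and on what is new or still open speak of the compounds shown alone.

Measured so far:
- Compound 1 `Cc1cc(NS(=O)(=O)c2ccc(N/C(S)=N\c3ccnc4cc(C(F)(F)F)ccc34)cc2)on1`: 27300 nM
- Compound 2 `Cc1noc(NS(=O)(=O)c2ccc(N/C(S)=N\c3ccnc4cc(C(F)(F)F)ccc34)cc2)c1C`: 27700 nM

Both numbers come from a functional assay on HT-1080 cells (Homo sapiens) for antiproliferative activity, read by sulforhodamine B assay, with a stated time of 48 h; a lower number here means a stronger inhibitor, a higher number a weaker inhibitor. On these two numbers compound 1 stands together with compound 2: the step of a 1.0-fold higher number from compound 1 to compound 2 (0.01 log units; within the scatter) is within the scatter, so neither can be called the stronger inhibitor.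

Compound 3 `Cc1cc(C)nc(NS(=O)(=O)c2ccc(N/C(S)=N\c3ccnc4cc(C(F)(F)F)ccc34)cc2)n1` has not been measured. It differs from compound 1 in one place: 4,6-dimethylpyrimidin-2-yl in place of 3-methyl-1,2-oxazol-5-yl on a sulfonamide nitrogen. This puts a new ring on the sulfonamide nitrogen, where the earlier change from compound 1 to compound 2 only added a methyl group to the ring already there.

Among the measured compounds shown here, only one measured step exists, and it bears on compound 3 only loosely, since it changes the same ring without replacing it. That step, a 1.0-fold higher number from compound 1 to compound 2 (0.01 log units; within the scatter), showed no movement beyond the scatter. With nothing else to go on, a step of no size beyond the scatter in this assay is expected, in neither direction, though a full ring swap leaves room for a larger surprise.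

For compound 3 the expected value in this assay is 27000 nM, with a range from 9000 nM to 80000 nM, which is an expected step of a 1.0-fold lower number from compound 1 to compound 3 (0.00 log units; within the scatter).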

Compound 3, half-maximal inhibitory concentration: 29500 nM
For compound 3 the middle estimate is 1.1-fold (0.04 log units) below the measured one, within the range that was stated.
By their numbers in this assay, from the lowest: compounds 1, 2 and 3 (each within the scatter of the next).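

In this assay, replacing the ring on the sulfonamide nitrogen outright gives a 1.1-fold higher number from compound 1 to compound 3 (0.03 log units; within the scatter) when 4,6-dimethylpyrimidin-2-yl enters in place of 3-methyl-1,2-oxazol-5-yl, and a 1.1-fold higher number from compound 2 to compound 3 (0.03 log units; within the scatter) when it enters in place of 3,4-dimethyl-1,2-oxazol-5-yl. The earlier methyl step only altered a ring already present, whereas these steps show that a different ring, six-membered and with 8 heavy atoms in place of 6, also produces no movement beyond the scatter at this position. No measurement here explains this result.

Going by these compounds, all three groups on this nitrogen are aromatic rings with 2 hetero atoms, so it remains open whether an open chain such as butyl, a plain phenyl ring, or a ring bearing a carboxylic acid or an amine would give a clearly different number. Also open, on these data alone, is whether changes elsewhere on the shared core, such as chlorine in place of the trifluoromethyl group, would move the number beyond the scatter, since every compound here carries the same core.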